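This account rests on a few compounds, and the source may have more. Where it says the series, first, only, none or still open, it means among the compounds named here.

Three compounds share one core. Compound 1 `O=C1c2cc(COc3ccccc3)nn2CCN1c1ccc(F)cc1` gives 79% in a functional assay on HEK293 cells for positive allosteric modulation of metabotropic glutamate receptor 5 (Homo sapiens), read by calcium flux (a higher number here means a larger maximal response, a lower number a smaller maximal response), the highest of the three values. Compound 2 `COc1ccc(N2CCn3nc(COc4ccccc4)cc3C2=O)cc1` gives 58%, and compound 3 `O=C1c2cc(COc3ccccc3)nn2CCN1c1cccnc1` gives 64%. Both measured steps away from the top value alter the aryl group on the amide-type nitrogen: a number 21 percentage points lower from compound 1 to compound 2 (beyond the scatter) and a number 15 percentage points lower from compound 1 to compound 3 (beyond the scatter); between the two lower values, a number 6 percentage points higher from compound 2 to compound 3 (within the scatter). Compound 4 `Cc1ccc(OCc2cc3n(n2)CCN(c2ccc(F)cc2)C3=O)cc1` differs from compound 1 elsewhere: methyl in place of hydrogen on an aromatic carbon, on the phenoxy side of the molecule. Among the measured compounds shown here, no measured step touches that side, so the data give no direction for this change, and no step beyond the scatter is assumed. For compound 4 the expected step is a number 4 percentage points lower from compound 1 to compound 4 (within the scatter). Compound 4 is estimated at 75%, ranging from 55% to 95%.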

Compound 4, largest response reached (Emax), in percent of the reference or control that the assay uses: 58%
For compound 4 the middle estimate is 17 percentage points above the measured one, and the stated range covers the measured number.
By their numbers in this assay, from the lowest: compounds 2, 4 and 3 (each within the scatter of the next); then compound 1.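

The phenoxy side is not silent in this assay: methyl in place of hydrogen, para to a large group, gives a number 21 percentage points lower from compound 1 to compound 4 (beyond the scatter) and so moves the maximal response beyond the scatter. Until now, only changes to the aryl group on the amide-type nitrogen had shown such a drop, so the top value of compound 1 also depends on this position. Nothing shown gives a reason for the drop. Going by these compounds, whether a chloro, a hydroxyl or an ethyl at this place would lower the response as well remains open. So does whether methyl here would have the same effect on compound 2 or compound 3.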